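The source may report more compounds than this note shows. Statements on the series, on what has been measured and on what is new or still open speak of the compounds shown alone.

- compound 1 `N#Cc1c(Nc2ccccc2)nc(SCc2nc3ccccc3[nH]2)nc1-c1ccccc1`: 2.4 nM
- compound 2 `CCNc1nc(SCc2nc3ccccc3[nH]2)nc(-c2ccccc2)c1C#N`: 4.38 nM
- compound 3 `N#Cc1c(NC(N)=S)nc(SCc2nc3ccccc3[nH]2)nc1-c1ccccc1`: 5.81 nM

These values come from a functional assay on G-361 cells (Homo sapiens) for cytotoxicity, read by MTT assay, with a stated time of 3 days; a higher number here means a weaker inhibitor, a lower number a stronger inhibitor. Compound 3 lies within the scatter of compound 2, while its number is beyond the scatter above that of compound 1. Compound 4 `N#Cc1c(-c2ccccc2)nc(SCc2nc3ccccc3[nH]2)nc1N1CCNCC1` carries a different group on the aromatic carbon: a group of 6 heavy atoms (4 carbon, 2 nitrogen; one six-membered non-aromatic ring with 2 hetero atoms) in place of a group of 4 heavy atoms (1 carbon, 2 nitrogen, 1 sulfur; no ring), on an aromatic carbon. Among the compounds with values here, no measured compound holds such a ring, so the nearest evidence is the set of changes in the group at this carbon: a 1.8-fold higher number from compound 1 to compound 2 (0.26 log units; within the scatter), a 1.3-fold higher number from compound 2 to compound 3 (0.12 log units; within the scatter) and a 2.4-fold higher number from compound 1 to compound 3 (0.38 log units; beyond the scatter). All three are small, so no step beyond the scatter is expected in this assay, in either direction. The expected change is a 1.1-fold lower number from compound 3 to compound 4 (0.02 log units; within the scatter). For compound 4 the estimated value is 5.5 nM, with an expected range of 2 nM to 15 nM.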

Compound 4, half-maximal inhibitory concentration: 2.5 nM
For compound 4 the middle estimate is 2.2-fold (0.34 log units) above the measured one; measured number inside the range.
By their numbers in this assay, from the lowest: compounds 1, 4, 2 and 3 (each within the scatter of the next, the first and the last beyond it).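

In this assay a non-aromatic ring at this aromatic carbon holds the number set by the open and aromatic amines: a 1.0-fold higher number from compound 1 to compound 4 (0.02 log units; within the scatter) and a 1.8-fold lower number from compound 2 to compound 4 (0.24 log units; within the scatter) both lie within the scatter. Only the thiourea-type group of compound 3 stands apart, and a 2.3-fold lower number from compound 3 to compound 4 (0.37 log units; beyond the scatter) is beyond the scatter but modest, while compound 3 remains within the scatter of compound 2. No measurement shown accounts for these differences.

As far as these compounds go, whether a morpholine ring here, or a methyl or longer chain on the second piperazine nitrogen, would keep these numbers stays open.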